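Series notes: methoxy count on the benzylamine ring

The compounds below may be only part of what the source reports. "The series", "measured", "known", "first", "only" and "open" are said of these compounds alone.

The series shares a core carrying two amino groups and a phenyl group, with a substituted benzyl group on the ring nitrogen. Compound 1 `Nc1cc(N)c2nc(-c3ccccc3)c(NCc3ccc(Cl)c(Cl)c3)nc2c1` gives 36300 nM in a functional assay on SK-OV-3 cells (Homo sapiens) for inhibition, read by sulforhodamine B assay, with a stated time of 48 h; on this read-out higher numbers stand for weaker inhibition of growth and lower numbers for stronger inhibition of growth. Compound 2 `COc1ccc(CNc2nc3cc(N)cc(N)c3nc2-c2ccccc2)cc1OC` gives 46800 nM in this assay. Of the two numbers, compound 2 stands at the upper end, though compound 1 lies within the scatter of it: the step of a 1.3-fold higher number from compound 1 to compound 2 (0.11 log units; within the scatter) is not a real change.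

Compound 3 `COc1cc(CNc2nc3cc(N)cc(N)c3nc2-c2ccccc2)cc(OC)c1OC` has not yet been measured. It differs from compound 2 by methoxy in place of hydrogen on an aromatic carbon. For the measured compounds named here, no measured step touches an added methoxy on this ring; the only step available, from compound 1 to compound 2, exchanged the whole substitution pattern of the ring and stayed within the scatter. Going by the values given here, with that as the sole guide, the expectation for compound 3 is a step of a 1.1-fold higher number from compound 2 to compound 3 (0.03 log units; within the scatter), that is, no change beyond the scatter in this assay. The estimate for compound 3 is therefore 50000 nM, with a range from 20000 nM to 125000 nM.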

Compound 3, concentration for total growth inhibition: 13800 nM
For compound 3 the middle estimate is 3.6-fold (0.56 log units) above the measured one, outside the stated range (below it).
By their numbers in this assay, from the lowest: compound 3; then compounds 1 and 2 (each within the scatter of the next).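

In this assay, for the compounds shown here, adding one methoxy to the benzylamine ring gives a 3.4-fold lower number from compound 2 to compound 3 (0.53 log units; beyond the scatter), the only step so far that lies beyond the scatter, so this ring can affect the read-out after all. The added group sits on an aromatic carbon ortho to a methoxy group, meta to a large group and meta to a methoxy group, and this single addition registers where the exchange of chloro for methoxy substituents gave only a 1.3-fold higher number from compound 1 to compound 2 (0.11 log units; within the scatter). Nothing available accounts for the step, which remains a bare observation on one pair of compounds.

Going by these compounds, whether the step is particular to methoxy remains open, as a hydroxyl, an ethoxy group or an amine on the same aromatic carbon would be needed to separate the effect of the group from that of simply filling the position. Also open, on these data alone, is whether the step depends on the two neighbouring methoxy groups of compound 2, since a single pair cannot show if the same addition would register on a ring carrying chloro substituents, as in compound 1.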